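The source may hold more compounds than are shown below. What is called first, only, known or untested is meant among the compounds shown, and "the series" means these compounds.

Measured so far in a physicochemical assay for solubility, in phosphate buffer, measured as kinetic solubility, with a stated time of 1 h, at pH 7.4; a lower number here means a less soluble compound, a higher number a more soluble compound:
compound 1 `COc1ccc2nc(C)cc(OCC(=O)Nc3ccccc3)c2c1` gives 63000 nM;
compound 2 `COc1ccc2nc(C)cc(OCC(=O)Nc3cc(C)c(OC)c(C)c3)c2c1` gives 17000 nM;
compound 3 `COc1ccc2nc(C)cc(OCC(=O)Nc3cc(C)c(F)c(C)c3)c2c1` gives 31500 nM.

Compound 3 stands second highest of the three numbers; its nearest neighbour is compound 2, with a 1.9-fold higher number from compound 2 to compound 3 (0.27 log units; within the scatter), its furthest compound 1, with a 2.0-fold lower number from compound 1 to compound 3 (0.30 log units; within the scatter), both within the scatter. Compound 4 `COc1ccc2nc(C)cc(OCC(=O)Nc3cccnc3)c2c1` is not yet measured; it differs from compound 3 as follows: pyridin-3-yl in place of 4-fluoro-3,5-dimethylphenyl on an amide-type nitrogen. Both measured steps concern the group on the same amide-type nitrogen and stayed within the scatter, so changes at this nitrogen have so far moved this assay little. The entering pyridin-3-yl brings one hydrogen-bond acceptor where the leaving group had none, a change untested in this set. For compound 4 the expected step is a 2.5-fold higher number from compound 3 to compound 4 (0.40 log units; beyond the scatter), a modest rise at most. The estimate for compound 4 is 80000 nM, in the range 30000 nM to 200000 nM.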

Compound 4, solubility: 32000 nM
The estimate for compound 4 lay 2.5-fold (0.40 log units) above the measured number; measured number inside the range.
By their numbers in this assay, from the lowest: compounds 2, 3, 4 and 1 (each within the scatter of the next, the first and the last beyond it).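

In this assay a ring with a hetero atom and a hydrogen-bond acceptor on the amide-type nitrogen gives a step within the scatter against 4-fluoro-3,5-dimethylphenyl (a 1.0-fold higher number from compound 3 to compound 4 (0.01 log units; within the scatter)). The one-place comparison with phenyl also stays within the scatter (a 2.0-fold lower number from compound 1 to compound 4 (0.29 log units; within the scatter)), so neither comparison shows a separate effect of the pyridin-3-yl nitrogen. No measurement at hand accounts for this result.

Open, on these data alone, is whether pyridin-4-yl would also stay within the scatter. Also open, as far as these compounds go, is whether an amine or a carboxylic acid on the ring at this nitrogen would give a step beyond it.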